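Chloro for Methyl on the Anilino Ring, Second Position

This account rests on a few compounds, and the source may have more. Where it says the series, first, only, none or still open, it means among the compounds named here.

Compound 1 `Cc1ccc(Nc2nc3c(=O)[nH]c(C)nc3s2)cc1` and compound 2 `Cc1nc2sc(Nc3ccc(Cl)cc3)nc2c(=O)[nH]1` were both tested in an assay on CHO cells for displacement of a labelled ligand from adenosine receptor A1 (Homo sapiens), read by scintillation counting, with a stated time of 120 min, tested at 1 uM; on this read-out higher numbers stand for more inhibition at the one concentration tested (going by the name of the read-out) and lower numbers for less inhibition. Compound 1 gives 20%, while compound 2 gives 33%. The change between them is chloro in place of methyl on an aromatic carbon, and it made a step of a number 13 percentage points higher from compound 1 to compound 2 (beyond the scatter). Compound 3 `Cc1cccc(Nc2nc3c(=O)[nH]c(C)nc3s2)c1` has the same atoms as compound 1 joined differently; how the two cores differ is not broken down here. In this assay compound 3 gives 12%. Compound 4 `Cc1nc2sc(Nc3cccc(Cl)c3)nc2c(=O)[nH]1` has not yet been measured. For the measured compounds named here, it differs from compound 3 by chloro in place of methyl on an aromatic carbon, the same kind of change as the one between compound 1 and compound 2, but here the place is meta to a large group rather than para to a large group. Compound 4 is expected to move by about the same amount, a number 13 percentage points higher from compound 3 to compound 4 (beyond the scatter), because a number 13 percentage points higher from compound 1 to compound 2 (beyond the scatter) was of that size. Compound 4 is therefore estimated at 25% in this assay, expected to fall between 10% and 40%.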

Compound 4, a percentage reported as inhibition, at one concentration (the size of the read-out at that concentration, not a potency): 44%
Estimate against measurement, compound 4: 19 percentage points below, and the stated range ends below it.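

In this assay, chloro in place of methyl gave a number 32 percentage points higher from compound 3 to compound 4 (beyond the scatter) on this second core, so the direction of the change held on both cores. The size of the step did not carry over: the same change on two cores in this assay, a number 13 percentage points higher (beyond the scatter) from compound 1 to compound 2 and a number 32 percentage points higher (beyond the scatter) from compound 3 to compound 4, 19 percentage points apart, beyond the scatter of two such steps. For the compounds shown here, with only two pairs, this shows that the step seen on one core cannot be taken as the size on the other, but it does not give a rule for predicting the size or show why the two steps differ.

The compounds shown carry only methyl or chloro on the six-membered aromatic ring of carbon only. Going by these compounds, how a methoxy group, a nitrile or an amine at that place would read remains open, as does whether any of these would follow chloro.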